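Swapping Acetyl for 3-Chlorophenyl: Expected Cytotoxicity of Compound 3

The source may report more compounds than this note shows. Statements on the series, on what has been measured and on what is new or still open speak of the compounds shown alone.

Measured compounds:
compound 1, `Cc1cc(C)c(Oc2cc(Nc3ccc(C#N)cc3)ncc2C(=O)NCc2cn(Cc3ccccc3C#N)nn2)c(C)c1`; in an ADME assay on MT4 cells (Homo sapiens) for cytotoxicity, read by MTT assay, with a stated time of 5 days (on this read-out lower numbers stand for higher toxicity in this test and higher numbers for lower toxicity in this test), compound 1 gives > 219000 nM, which is a limit of the assay and not a number.
compound 2, `CC(=O)Cn1cc(CNC(=O)c2cnc(Nc3ccc(C#N)cc3)cc2Oc2c(C)cc(C)cc2C)nn1`; in this assay compound 2 gives 19400 nM.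

Compound 2 holds the only plain number shown in this assay; the one other value is a limit. Compound 3, `Cc1cc(C)c(Oc2cc(Nc3ccc(C#N)cc3)ncc2C(=O)NCc2cn(Cc3cccc(Cl)c3)nn2)c(C)c1`, differs from compound 2 in a single place: 3-chlorophenyl in place of acetyl on a saturated chain carbon bound to an aromatic nitrogen. Among the compounds with values here, one measured step bears on this change, an at least 11-fold lower number from compound 1 to compound 2 (1.05 log units; beyond the scatter), in which a 2-cyanophenyl in the same place gave way to the acetyl. Compound 1 sits at the limit of > 219000 nM in this assay, at which 1 of the 2 values shown sits. The change from compound 2 to compound 3 runs the other way, putting a six-membered aromatic ring of carbon back on that saturated chain carbon, so a large step in this assay toward a higher number is expected, with a real chance that only a limit is reported again. Compound 3 is therefore expected to give about 150000 nM, somewhere between 40000 nM and 300000 nM. That expectation corresponds to the step of a 7.7-fold higher number from compound 2 to compound 3 (0.89 log units; beyond the scatter).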

Compound 3, half-maximal cytotoxic concentration: 187000 nM
For compound 3 the middle estimate is 1.2-fold (0.10 log units) below the measured one; measured number inside the range.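

In this assay the replacement of acetyl by 3-chlorophenyl on a saturated chain carbon bound to an aromatic nitrogen gives a 9.6-fold higher number from compound 2 to compound 3 (0.98 log units; beyond the scatter), which shows that the higher number is not confined to 2-cyanophenyl at this place: among the three compounds, both that carry a six-membered aromatic ring of carbon there stand higher than the acetyl compound, and none goes against this. The two ring-bearing compounds cannot be placed in order, with an at least 1.1-fold lower number from compound 1 to compound 3 (0.06 log units; that floor lies within the scatter), and the position of the chlorine against that of the nitrile remains unresolved. Compound 1 is reported only as a limit of the assay: the limit of > 219000 nM in this assay, at which 1 of the 3 values shown sits.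

Acetyl is the only group without a ring at this place, and the three compounds do not separate the presence of the aromatic ring from the loss of acetyl itself. On these data alone, whether an unsubstituted phenyl, a saturated cyclohexyl ring or an amine on a longer chain would stand with compound 2 or with compound 3 in this assay remains open.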